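Ring-nitrogen aryl swap: compound 1 to compound 3

The compounds below may be only part of what the source reports. "The series", "measured", "known", "first", "only" and "open" are said of these compounds alone.

Measured so far:
compound 1 `COc1ccc(OC)c(N2C(=O)CSC2c2cccc(C(=O)NCCCCc3ccccc3)c2)c1` — > 1000 nM
compound 2 `COc1ccccc1N1C(=O)CSC1c1cc(F)cc(C(=O)NCCCCc2ccccc2)c1` — 40.9 nM

In a functional assay on HOS-TE85 cells (Homo sapiens) for inhibition, read by CCK-8 assay, with a stated time of 72 h (on this read-out higher numbers stand for weaker inhibition and lower numbers for stronger inhibition), compound 1 gives > 1000 nM, which is a limit of the assay and not a number (the limit of > 1000 nM in this assay, at which 1 of the 2 values shown sits). Compound 2 gives 40.9 nM in this assay, a full value well inside the measured range. Compound 3 `O=C(NCCCCc1ccccc1)c1cccc(C2SCC(=O)N2c2cnccn2)c1` differs from compound 1 by pyrazin-2-yl in place of 2,5-dimethoxyphenyl on an amide-type nitrogen in a ring. Going by the values given here, no measured step joins these two, so the direction rests on compound 1 sitting at the limit: the step of an at least 1.6-fold lower number from compound 1 to compound 3 (0.22 log units; that floor lies within the scatter) is expected to run toward stronger inhibition, likely beyond the scatter but short of compound 2. Compound 3 is estimated at 600 nM, between 150 nM and 2500 nM.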

Compound 3, half-maximal inhibitory concentration: > 1000 nM
Compound 3 ended at the assay's limit (the forecaster's own chance of this, stated with the estimate: 40%); middle value at least 1.6-fold (0.22 log units) away from the limit.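

Compound 1 and compound 3 both give a limit and not a number, so no step between them can be read: the limit of > 1000 nM in this assay, at which 2 of the 3 values shown sit.

As far as these compounds go, whether pyrazin-2-yl in place of 2,5-dimethoxyphenyl changes inhibition at all remains open.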